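Aminophenyl Replaces Fluoropyridinyl on a Thienopyridine Core

The source may hold more compounds than are shown below. What is called first, only, known or untested is meant among the compounds shown, and "the series" means these compounds.

Compound 1 `COC(=O)c1sc2cc(-c3ccsc3)cnc2c1N`: 12100 nM in a functional assay on A-375 cells (Homo sapiens) for inhibition, read by sulforhodamine B assay, with a stated time of 48 h; on this read-out higher numbers stand for weaker inhibition of growth and lower numbers for stronger inhibition of growth
Compound 2 `COC(=O)c1sc2cc(-c3cnn(C)c3)cnc2c1N`: > 150000 nM, a limit of this assay
Compound 3 `COC(=O)c1sc2cc(-c3ccc(F)nc3)cnc2c1N`: "not determined" (no result reported) in this assay
Compound 4 `COC(=O)c1sc2cc(-c3ccccc3N)cnc2c1N`: not yet measured

For the measured compounds named here, compound 3 stands nowhere on the numbers: in this assay no result was reported for it, and the only other value shown beside compound 1 is a limit. The step to compound 4 is 2-aminophenyl in place of 6-fluoropyridin-3-yl on an aromatic carbon. Going by the values given here, the one measured step, an at least 12-fold higher number from compound 1 to compound 2 (1.09 log units; beyond the scatter), ends at the limit of > 150000 nM in this assay, at which 1 of the 3 values shown sits, so the aromatic group at this position can move the number strongly. Among the compounds with values here, no measured step involves a carbocyclic ring, so no direction can be taken from it. Compound 4 is expected to give about 20000 nM, within 3000 nM to 150000 nM.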

Compound 4, concentration for 50% growth inhibition: 2500 nM
The estimate for compound 4 lay 8.0-fold (0.90 log units) above the measured number; measured number below the stated range.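

In this assay a ring of carbon only now stands at this position, and 2-aminophenyl gives a 4.8-fold lower number from compound 1 to compound 4 (0.68 log units; beyond the scatter) in the lowest number of the series, so the thiophen-3-yl of compound 1 is not the best group shown here. The gain over the pyrazole is larger, with an at least 60-fold lower number from compound 2 to compound 4 (1.77 log units; beyond the scatter) on the same position. The value of compound 2 is a limit, so the true size of that step stays unknown: the limit of > 150000 nM in this assay, at which 1 of the 4 values shown sits.

The step from compound 3 to compound 4 cannot be read. The compounds shown leave open whether the amine or the ring of carbon only carries the change, which an unsubstituted phenyl or a hydroxyl in place of the amine would separate.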